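Removing One Pyridinylmethyl Arm from a Chemokine Receptor Agonist

The compounds below may be only part of what the source reports. "The series", "measured", "known", "first", "only" and "open" are said of these compounds alone.

Of the compounds shown here, three built on one shared core have been tested in a functional assay on cells for agonist activity at C-X-C chemokine receptor type 4 (Homo sapiens), read by fluorescence and calcium flux, with a stated time of 90 s; a lower number here means that less compound is needed, a higher number that more compound is needed for the effect. Compound 1 `c1cncc(CN(CCCCN(C[C@H]2Cc3ccccc3CN2)[C@H]2CCCc3cccnc32)Cc2cccnc2)c1` reaches only a limit of the assay, > 30000 nM. Compound 2 `c1ccc2c(c1)CN[C@@H](CN(CCCCN(Cc1ccncc1)Cc1ccncc1)[C@H]1CCCc3cccnc31)C2` also reports a limit rather than a number, > 30000 nM. Compound 3 `c1ccc(CN(CCCCN(C[C@H]2Cc3ccccc3CN2)[C@H]2CCCc3cccnc32)Cc2ccccc2)cc1` stops at a limit as well, > 30000 nM. Going by the values given here, every result so far therefore sits at the limit of > 30000 nM in this assay, at which 3 of the 3 values shown sit, and no step between measured compounds can be sized or given a direction. Compound 4 `c1ccc2c(c1)CN[C@@H](CN(CCCCNCc1ccncc1)[C@H]1CCCc3cccnc31)C2` is compound 2 with one change: hydrogen in place of (pyridin-4-yl)methyl on an amine nitrogen. Among the compounds with values here, with no measured step to lean on, the expected step is a step that the limit leaves unreadable from compound 2 to compound 4, no larger than the usual scatter. Compound 4 is accordingly estimated at 40000 nM, with a range from 8000 nM to 200000 nM, and most probably this assay will again report only a limit.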

Compound 4, half-maximal effective concentration: > 30000 nM
Compound 4 gave a limit, no number (the forecaster's own chance of this, stated with the estimate: 80%); the middle value lies beyond the limit too.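

No step from compound 2 to compound 4 can be read, since each result is only a limit: the limit of > 30000 nM in this assay, at which 4 of the 4 values shown sit.

The compounds shown leave open how much replacing (pyridin-4-yl)methyl with hydrogen changes the response in this assay.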